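Adding a second methoxy to compound 2

The source may hold more compounds than are shown below. What is called first, only, known or untested is meant among the compounds shown, and "the series" means these compounds.

Measured so far in a functional assay on SGC-7901 cells (Homo sapiens) for antiproliferative activity, read by MTT assay, with a stated time of 48 h; a higher number here means a weaker inhibitor, a lower number a stronger inhibitor:
Compound 1 `Cc1ccc(-c2nnc(SCc3ccc(Cl)nc3)o2)cc1`: 3.62 ug/mL
Compound 2 `COc1ccc(-c2nnc(SCc3ccc(Cl)nc3)o2)cc1`: 3.5 ug/mL

The two values lie within the scatter of each other, so compound 2 cannot be ranked against compound 1 in this assay. Within the data shown here, the only measured step is a 1.0-fold lower number from compound 1 to compound 2 (0.01 log units; within the scatter), where methoxy stands in place of methyl on an aromatic carbon.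

Compound 3 `COc1ccc(-c2nnc(SCc3ccc(Cl)nc3)o2)cc1OC` has methoxy in place of hydrogen on an aromatic carbon, ortho to a methoxy group and meta to a large group (methoxy in place of hydrogen on an aromatic carbon). Among the measured compounds shown here, no measured step makes this same change, so the step to compound 1 bears on it only loosely. With that single small step as the guide, no change beyond the scatter is expected. The expected step is a 1.0-fold higher number from compound 2 to compound 3 (0.01 log units; within the scatter). For compound 3 the estimated value is 3.6 ug/mL, with an expected range of 1.6 ug/mL to 8 ug/mL.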

Compound 3, half-maximal inhibitory concentration: 4.48 ug/mL
Compound 3: middle estimate off by 1.2-fold (0.09 log units), on the low side; the range from low to high includes it.
By their numbers in this assay, from the lowest: compounds 2, 1 and 3 (each within the scatter of the next).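

In this assay the added methoxy on this aromatic carbon, ortho to a methoxy group and meta to a large group, gives a 1.3-fold higher number from compound 2 to compound 3 (0.11 log units; within the scatter) and so produces no readable change at this position. Among these compounds, this is the first look at a substituent added to the ring rather than exchanged, and like the earlier exchange of methyl for methoxy, which gives a 1.0-fold lower number from compound 1 to compound 2 (0.01 log units; within the scatter), it stays within the scatter. No measured property bears on this result.

On these data alone, whether this position stays just as unresponsive to a different kind of group, such as an amine or a carboxylic acid, remains open. Also open, as far as these compounds go, is what a longer chain, such as ethoxy, would do in place of either methoxy group in compound 3.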